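This account rests on a few compounds, and the source may have more. Where it says the series, first, only, none or still open, it means among the compounds named here.

In a functional assay on NCI-H1993 cells (Homo sapiens) for inhibition, read by CCK-8 assay, with a stated time of 72 h (on this read-out higher numbers stand for weaker inhibition and lower numbers for stronger inhibition), three compounds sharing one core have been measured. Compound 1 `c1cnc2ccc(Cn3cnc4ncc(-c5cn[nH]c5)nc43)cc2c1` gives 2890 nM, compound 2 `OCCn1cc(-c2cnc3ncn(Cc4ccc5ncccc5c4)c3n2)cn1` gives 2330 nM and compound 3 `Nc1ccc(-c2cnc3ncn(Cc4ccc5ncccc5c4)c3n2)cc1` gives 4950 nM. Two steps place compound 3 among them: a 1.7-fold higher number from compound 1 to compound 3 (0.23 log units; within the scatter), and a 2.1-fold higher number from compound 2 to compound 3 (0.33 log units; beyond the scatter). The remaining step, on an aromatic nitrogen and not at the carbon that changes next, is a 1.2-fold lower number from compound 1 to compound 2 (0.09 log units; within the scatter).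

Compound 4 `Fc1ccccc1-c1cnc2ncn(Cc3ccc4ncccc4c3)c2n1` carries 2-fluorophenyl in place of 4-aminophenyl on an aromatic carbon. Among the measured compounds shown here, no measured compound holds this group, so the data offer no direct precedent. The two steps that replace a group at this same carbon are the ones that bear on the change, and neither is more than modest. Compound 4 is therefore expected to stay close to compound 3, with no change beyond the scatter. The expected step is a 1.2-fold lower number from compound 3 to compound 4 (0.09 log units; within the scatter). For compound 4 the estimated value is 4000 nM, within an expected range of 1600 nM to 10000 nM.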

Compound 4, half-maximal inhibitory concentration: > 10000 nM
Compound 4: only a limit was reported (the forecaster's own chance of this, stated with the estimate: 12%); middle value at least 2.5-fold (0.39 log units) away from the limit.
By their numbers in this assay, from the lowest: compounds 2, 1 and 3 (each within the scatter of the next, the first and the last beyond it). At a limit, above all of these: compound 4.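

Compound 4 gave no number in this assay, only a limit: the limit of > 10000 nM in this assay, at which 1 of the 4 values shown sits. At this aromatic carbon, next to the ring nitrogen, 2-fluorophenyl is the only group shown to open a clear gap from 1H-pyrazol-4-yl, an at least 3.4-fold higher number from compound 1 to compound 4 (0.53 log units; beyond the scatter), and from 1-(2-hydroxyethyl)-1H-pyrazol-4-yl, an at least 4.2-fold higher number from compound 2 to compound 4 (0.63 log units; beyond the scatter), whereas the earlier replacements here were modest at most. Against 4-aminophenyl the change can be read only as a floor, an at least 2.0-fold higher number from compound 3 to compound 4 (0.30 log units; that floor lies within the scatter), so it is not settled that this change goes beyond the scatter.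

The compounds shown leave open whether the gain of fluorine, the loss of the amine or the change of substitution place on the phenyl ring accounts for these gaps. A plain phenyl, a 4-fluorophenyl or a 2-aminophenyl group at this carbon would separate those three.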